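Methoxy in place of hydrogen: cytotoxicity of compound 4

This account rests on a few compounds, and the source may have more. Where it says the series, first, only, none or still open, it means among the compounds named here.

compound 1 `c1ccc(-c2cnc(Nc3ccc4[nH]ncc4c3)o2)cc1`: a limit only, > 90 uM, in an ADME assay on MT4 cells (Homo sapiens) for cytotoxicity, read by WST assay; on this read-out lower numbers stand for higher toxicity in this test and higher numbers for lower toxicity in this test
compound 2 `Clc1ccccc1-c1cnc(Nc2ccc3[nH]ncc3c2)o1`: a limit only, > 100 uM, in this assay
compound 3 `Clc1ccc(-c2cnc(Nc3ccc4[nH]ncc4c3)o2)cc1`: a limit only, > 90 uM, in this assay

Compound 1 thus stands only at a limit in this assay, and the other two compounds do the same. The step that the two limits leave unreadable from compound 1 to compound 2 and the step that the two limits leave unreadable from compound 1 to compound 3 are both unreadable for this reason; the limit of > 90 uM in this assay, at which 2 of the 3 values shown sit, holds two of the three values and the limit of > 100 uM in this assay, at which 1 of the 3 values shown sits, the third. Compound 4 `COc1cccc(-c2cnc(Nc3ccc4[nH]ncc4c3)o2)c1` differs from compound 1 by methoxy in place of hydrogen on an aromatic carbon. Since the two measured single changes on this ring gave no readable step, no step beyond the scatter is expected for a step that the limit leaves unreadable from compound 1 to compound 4. Compound 4 is therefore expected to give 95 uM in this assay, within 45 uM to 200 uM, most likely again reported only as a limit.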

Compound 4, half-maximal toxic concentration: > 90 uM
Compound 4: a limit, no number; the forecaster's own chance of this, stated with the estimate: 80%; the middle value lies beyond the limit too.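

Within the data shown here, compound 1 and compound 4 both stand only at a limit in this assay, and no step between them can be read. The compounds shown leave open the concentration at which any of them becomes toxic in this assay, and whether methoxy or chloro changes it.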